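Thiophen-3-yl for thiazolyl on the amide carbonyl

The compounds below may be only part of what the source reports. "The series", "measured", "known", "first", "only" and "open" are said of these compounds alone.

- compound 1 `CCCCCCCCCCCC[C@@H](O)[C@H]1CC[C@H]([C@H](O)CCCCCCCCCCNC(=O)c2cccs2)O1` gives 2570 nM
- compound 2 `CCCCCCCCCCCC[C@@H](O)[C@H]1CC[C@H]([C@H](O)CCCCCCCCCCNC(=O)c2cncs2)O1` gives 100000 nM

Of the two measured compounds in a functional assay on MDA-MB-231 cells (Homo sapiens) for inhibition, read by colorimetric assay and sulforhodamine B assay, with a stated time of 48 h (a lower number here means a stronger inhibitor of growth, a higher number a weaker inhibitor of growth), compound 2 holds the higher number, at 100000 nM. The next compound is compound 3 `CCCCCCCCCCCC[C@@H](O)[C@H]1CC[C@H]([C@H](O)CCCCCCCCCCNC(=O)c2ccsc2)O1`, which carries thiophen-3-yl in place of 1,3-thiazol-5-yl on a carbonyl carbon. Going by the values given here, one measured step bears on this change. The large step of a 39-fold higher number from compound 1 to compound 2 (1.59 log units; beyond the scatter), beyond the scatter, came with 1,3-thiazol-5-yl replacing thiophen-2-yl at the same carbonyl carbon. The present change leaves the same group, so a large move to a lower number is expected, landing near compound 1 at 2570 nM. Among the compounds with values here, no thiophen-3-yl compound has been measured yet, so the match with thiophen-2-yl remains untested. The expected step is a 29-fold lower number from compound 2 to compound 3 (1.46 log units; beyond the scatter). The estimate for compound 3 is 3500 nM, with an expected range of 900 nM to 20000 nM.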

Compound 3, concentration for 50% growth inhibition: 4470 nM
For compound 3 the middle estimate is 1.3-fold (0.11 log units) below the measured one; measured number inside the range.
By their numbers in this assay, from the lowest: compounds 1 and 3 (each within the scatter of the next); then compound 2.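

In this assay, thiophen-3-yl in place of 1,3-thiazol-5-yl on the carbonyl carbon gives a 22-fold lower number from compound 2 to compound 3 (1.35 log units; beyond the scatter) and thus shows that the large loss seen with the 1,3-thiazol-5-yl amide is not shared by both thiophene amides. Moving from thiophen-2-yl to thiophen-3-yl gives a 1.7-fold higher number from compound 1 to compound 3 (0.24 log units; within the scatter) and so does not separate the two thiophene attachments in this small set, whereas the ring with a nitrogen alongside the sulfur stands apart from both. Nothing measured on these compounds accounts for the gap between the thiophene amides and the 1,3-thiazol-5-yl amide.

From the compounds shown here alone, whether other thiazole attachments follow 1,3-thiazol-5-yl remains open. Going by these compounds, it is also open whether a phenyl or furan-2-yl ring on the same carbonyl carbon stays level with the thiophene amides, or whether a shorter or longer chain to the amide nitrogen shifts growth inhibition.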